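A few compounds are considered here, and "the series" means these few. Any claim that something is new, unique, unknown or untested is made for them only; others in the source may bear on it.

Compound 1 `CCOC(=O)Cn1cc(CNC(=O)c2cn(CCOC(C)=O)nn2)nn1`: > 100000 nM
Compound 2 `CC(=O)OCCn1cc(CNC(=O)c2cn(CCOC(C)=O)nn2)nn1`: > 100000 nM
Compound 3 `CCOC(=O)Cn1cc(-c2cccc(NC(=O)c3cn(CCOC(C)=O)nn3)c2)nn1`: 63000 nM

Of the compounds shown here, three have so far been measured in a functional assay on B16 cells (Mus musculus) for cytotoxicity, read by MTT assay, with a stated time of 48 h; a lower number here means a stronger inhibitor, a higher number a weaker inhibitor. Compound 1 `CCOC(=O)Cn1cc(CNC(=O)c2cn(CCOC(C)=O)nn2)nn1` gives > 100000 nM, which is a limit of the assay and not a number. Compound 2 `CC(=O)OCCn1cc(CNC(=O)c2cn(CCOC(C)=O)nn2)nn1` gives > 100000 nM, again a limit. Compound 2 differs from compound 1 by acetoxymethyl in place of ethoxycarbonyl on a saturated chain carbon bound to an aromatic nitrogen. The step that the two limits leave unreadable from compound 1 to compound 2 therefore has no readable size, because both values sit at the limit of > 100000 nM in this assay, at which 2 of the 3 values shown sit.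

Compound 3 `CCOC(=O)Cn1cc(-c2cccc(NC(=O)c3cn(CCOC(C)=O)nn3)c2)nn1` carries a different core; how its core differs from that of compound 1 is not broken down here. In this assay, for the measured compounds named here, compound 3 gives 63000 nM, the only actual number among the three values.

Compound 4 `CC(=O)OCCn1cc(C(=O)Nc2cccc(-c3cn(CCOC(C)=O)nn3)c2)nn1` has not yet been measured. It differs from compound 3 by acetoxymethyl in place of ethoxycarbonyl on a saturated chain carbon bound to an aromatic nitrogen, the same change as that made from compound 1 to compound 2, at the same place. Going by the values given here, since that earlier step is unreadable, the only footing for compound 4 is the value of compound 3 itself. The step to compound 4 is expected to be small, no change at the digits printed from compound 3 to compound 4 (within the scatter), resting on the value of compound 3, 63000 nM, and on the earlier pair giving no sign of a shift in either direction. For compound 4 the expected value in this assay is 63000 nM, estimated to lie between 25000 nM and 150000 nM.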

Compound 4, half-maximal inhibitory concentration: > 100000 nM
Compound 4 ended at the assay's limit (the forecaster's own chance of this, stated with the estimate: 35%); at least 1.5-fold (0.20 log units) between middle value and limit.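

In this assay, for the compounds shown here, the exchange of ethoxycarbonyl for acetoxymethyl on the core of compound 3 reads as an at least 1.5-fold higher number from compound 3 to compound 4 (0.20 log units; that floor lies within the scatter), so the one readable instance of this change points towards a higher number, but only by a floor that stays within the scatter. Compound 4 gives > 100000 nM, which is a limit of the assay and not a number. The same change on the core of compound 1 cannot be read, so there is no second size to set beside this one, and the series does not show whether the change carries over from one core to the other with the same size or even the same direction: the limit of > 100000 nM in this assay, at which 3 of the 4 values shown sit.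

The compounds shown leave open whether any other group at this place on the chain would give a value clear of that limit, such as a free carboxylic acid in place of the ethoxycarbonyl, a primary amine in place of the acetoxymethyl, or a longer chain carrying either ester. Also open is what sets compound 3, at 63000 nM, apart from the others, as no pair shown changes the core alone.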